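The source may report more compounds than this note shows. Statements on the series, on what has been measured and on what is new or still open speak of the compounds shown alone.

Measured so far: compound 1 `N#C/N=C(/NCCCCc1c[nH]cn1)NCCCc1ccccc1` with 5.25 in an in vitro functional assay on Sf9 cells for antagonist activity at histamine H2 receptor (Homo sapiens); on this read-out higher numbers stand for higher potency (the scale is a negative logarithm) and lower numbers for lower potency; compound 2 `N#C/N=C(/NCCCCc1c[nH]cn1)NCCCc1ccncc1` with 5.11 in this assay.

Compound 2 stands lowest of the two numbers, its nearest neighbour being compound 1, with a number 0.14 log units lower from compound 1 to compound 2 (within the scatter). Compound 3 `CN/C(=N\C#N)NCCCCc1c[nH]cn1` is not yet measured. Its change from compound 2 is hydrogen in place of 2-(pyridin-4-yl)ethyl on a saturated chain carbon bound to an amine nitrogen. Among the measured compounds shown here, the one measured step, phenyl to pyridin-4-yl, concerns only the aromatic end of the chain that is now removed entirely, and it was within the scatter; it does not bear directly on the loss of the whole 2-(pyridin-4-yl)ethyl group. For the measured compounds named here, no measured pair shows removal of this chain, so the expectation rests on the narrow spread between compound 1 and compound 2 alone. For compound 3 the expected step is a number 0.09 log units higher from compound 2 to compound 3 (within the scatter), with wide uncertainty. The estimate for compound 3 in this assay is 5.2, expected to fall between 4.5 and 5.9.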

Compound 3, negative logarithm of the antagonist equilibrium constant: < 5
Compound 3: only a limit was reported; the forecaster's own chance of this, stated with the estimate: 10%; middle value at least 0.20 log units from the limit.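

Compound 3 is reported in this assay only as a limit of the assay, < 5: the limit of < 5 in this assay, at which 1 of the 3 values shown sits. Hydrogen in place of 2-(pyridin-4-yl)ethyl gives a number at least 0.11 log units lower from compound 2 to compound 3 (that floor lies within the scatter), and hydrogen in place of phenethyl gives a number at least 0.25 log units lower from compound 1 to compound 3 (that floor lies within the scatter). Unlike the swap of phenyl for pyridin-4-yl, this change removes the whole chain at this place, and its true size has no lower bound: it may be large, or it may stay within the scatter.

The compounds shown leave open how far the true value of compound 3 lies from its limit. They also leave open whether the aromatic ring or the chain alone accounts for any difference, a question that a plain propyl group at this place would address.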